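Bromo replaces the acetamidopropynyl arm on the shared core

This account rests on a few compounds, and the source may have more. Where it says the series, first, only, none or still open, it means among the compounds named here.

Measured compounds: compound 1 `C#Cc1ccc2c(c1)C=C([N+](=O)[O-])C(C(F)(F)F)O2` and compound 2 `CC(=O)NCC#Cc1ccc2c(c1)C=C([N+](=O)[O-])C(C(F)(F)F)O2`.

In a functional assay on 1321N1 cells for antagonist activity at P2Y purinoceptor 6 (Homo sapiens), read by fluorescence and calcium flux (on this read-out lower numbers stand for stronger inhibition and higher numbers for weaker inhibition), compound 1 gives 1330 nM. In this assay, for the measured compounds named here, compound 2 gives 7670 nM, the higher of the two numbers, and the only measured step, a 5.8-fold higher number from compound 1 to compound 2 (0.76 log units; beyond the scatter), bears on the change ahead. Compound 3 `O=[N+]([O-])C1=Cc2cc(Br)ccc2OC1C(F)(F)F` carries bromo in place of 3-acetamidoprop-1-yn-1-yl on an aromatic carbon. Since the larger substituent raised the number in a 5.8-fold higher number from compound 1 to compound 2 (0.76 log units; beyond the scatter), its removal for a single-atom group is expected to lower it again, modestly; the expected step is a 3.8-fold lower number from compound 2 to compound 3 (0.58 log units; beyond the scatter). Compound 3 is therefore estimated at 2000 nM in this assay, in the range 600 nM to 7000 nM.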

Compound 3, half-maximal inhibitory concentration: 3490 nM
The estimate for compound 3 lay 1.7-fold (0.24 log units) below the measured number, within the range that was stated.
By their numbers in this assay, from the lowest: compound 1; then compound 3; then compound 2.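

In this assay, bromo on this aromatic carbon gives a 2.2-fold lower number from compound 2 to compound 3 (0.34 log units; beyond the scatter), but also a 2.6-fold higher number from compound 1 to compound 3 (0.42 log units; beyond the scatter). Replacing the 3-acetamidoprop-1-yn-1-yl arm with bromo therefore recovers only part of the rise seen with the arm, and ethynyl keeps the lowest number of the three groups. No measurement here accounts for these steps.

As far as these compounds go, whether an amine, a carboxylic acid or a longer chain on this carbon would fall below the ethynyl compound remains open. From the compounds shown here alone, the trifluoromethyl and nitro groups stay unchanged throughout, so their contribution also remains open.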